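Swapping Methoxy for Chloro on the Attached Phenyl Ring

A few compounds are considered here, and "the series" means these few. Any claim that something is new, unique, unknown or untested is made for them only; others in the source may bear on it.

Three compounds share one core and differ only in the group carried on the attached phenyl ring. In a functional assay on CCRF-CEM cells (Homo sapiens) for inhibition (a higher number here means a weaker inhibitor, a lower number a stronger inhibitor), compound 1 `CC(=O)OC[C@H]1O[C@@H](n2cnc3c(-c4ccc(F)cc4)ncnc32)[C@H](OC(C)=O)[C@@H]1OC(C)=O` gives 4000 nM, compound 2 `CC(=O)OC[C@H]1O[C@@H](n2cnc3c(-c4ccccc4)ncnc32)[C@H](OC(C)=O)[C@@H]1OC(C)=O` gives 10500 nM, and compound 3 `COc1ccc(-c2ncnc3c2ncn3[C@@H]2O[C@H](COC(C)=O)[C@@H](OC(C)=O)[C@H]2OC(C)=O)cc1` gives 4300 nM. Compound 3 therefore stands second highest of the three, close to compound 1 within the scatter, and a 2.4-fold lower number from compound 2 to compound 3 (0.39 log units; beyond the scatter). Compound 4 `CC(=O)OC[C@H]1O[C@@H](n2cnc3c(-c4ccc(Cl)cc4)ncnc32)[C@H](OC(C)=O)[C@@H]1OC(C)=O` carries a different group on that aromatic carbon: chloro in place of methoxy on an aromatic carbon. Within the data shown here, no measured step involves chloro. The steps of a 1.1-fold higher number from compound 1 to compound 3 (0.03 log units; within the scatter) and a 2.6-fold higher number from compound 1 to compound 2 (0.42 log units; beyond the scatter) show that fluoro and methoxy give similar numbers, while hydrogen in place of fluoro gives a weaker inhibitor. Chloro is expected to behave much like fluoro, so compound 4 is estimated at 3500 nM, between 1500 nM and 8000 nM, a step of a 1.2-fold lower number from compound 3 to compound 4 (0.09 log units; within the scatter).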

Compound 4, half-maximal inhibitory concentration: 4300 nM
Compound 4: middle estimate off by 1.2-fold (0.09 log units), on the low side, and the stated range covers the measured number.
By their numbers in this assay, from the lowest: compounds 1, 3 and 4 (each within the scatter of the next); then compound 2.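

Chloro and methoxy on this aromatic carbon read alike (no change at the digits printed from compound 3 to compound 4 (within the scatter)), and so do chloro and fluoro (a 1.1-fold higher number from compound 1 to compound 4 (0.03 log units; within the scatter)). Three quite different groups therefore sit within the scatter of one another, and only hydrogen stands apart (a 2.4-fold lower number from compound 2 to compound 4 (0.39 log units; beyond the scatter)). Nothing available explains why these three groups read alike. As far as these compounds go, whether an amine, a carboxylic acid or a longer chain at this spot would stay level with these three, or would shift the number in either direction, remains open.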